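From a hydroxy chain to an amino hydroxy chain

The source may hold more compounds than are shown below. What is called first, only, known or untested is meant among the compounds shown, and "the series" means these compounds.

Values in a functional assay on HT cells (Homo sapiens) for antiproliferative activity, read by fluorescence, with a stated time of 72 h (on this read-out higher numbers stand for weaker inhibition of growth and lower numbers for stronger inhibition of growth), so far:
compound 1 `CC(C)c1n[nH]c2c(NCc3ccc(-c4ccccn4)cc3)nc(SCC(N)CN)nc12` gives 480 nM
compound 2 `CC(C)c1n[nH]c2c(NCc3ccc(-c4ccccn4)cc3)nc(SCC3CNC(=O)O3)nc12` gives 80 nM
compound 3 `CC(O)CSc1nc(NCc2ccc(-c3ccccn3)cc2)c2[nH]nc(C(C)C)c2n1` gives 62 nM

Compound 3 stands at the low end of these numbers, level within the scatter with its nearest neighbour (a 1.3-fold lower number from compound 2 to compound 3 (0.11 log units; within the scatter)). Its furthest neighbour lies clearly apart (a 7.7-fold lower number from compound 1 to compound 3 (0.89 log units; beyond the scatter)).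

Compound 4 `CC(C)c1n[nH]c2c(NCc3ccc(-c4ccccn4)cc3)nc(SCC(O)CN)nc12` differs from compound 3 by a single change (amino in place of hydrogen on a saturated chain carbon, two bonds along the chain from an oxygen on a saturated carbon), which turns 2-hydroxypropyl into 3-amino-2-hydroxypropyl. Among the compounds with values here, no measured step makes this exact change, so the evidence is indirect. Among the three measured compounds, only compound 1 carries amino groups on its chain, as 1,2-diaminoethyl, and both steps away from it go to lower numbers (a 6.0-fold lower number from compound 1 to compound 2 (0.78 log units; beyond the scatter); a 7.7-fold lower number from compound 1 to compound 3 (0.89 log units; beyond the scatter)). Read in reverse, these steps suggest that amino on the chain goes with a higher number. Within the data shown here, compound 4 keeps the hydroxy group of compound 3 and gains only one amino group, so a rise smaller than those steps seems likely in this assay. The expected step is modest and upward (a 2.6-fold higher number from compound 3 to compound 4 (0.41 log units; beyond the scatter)). The expected value for compound 4 is 160 nM within an estimated range of 60 nM to 400 nM for now.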

Compound 4, concentration for 50% growth inhibition: 55 nM
The estimate for compound 4 lay 2.9-fold (0.46 log units) above the measured number; the measured number lies below the stated range.
By their numbers in this assay, from the lowest: compounds 4, 3 and 2 (each within the scatter of the next); then compound 1.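

In this assay, amino in place of hydrogen on a saturated chain carbon, two bonds along the chain from an oxygen on a saturated carbon, now has a direct reading, and the two compounds stand level (a 1.1-fold lower number from compound 3 to compound 4 (0.05 log units; within the scatter)). Compound 4 is also level with the cyclic carbamate chain of compound 2 (a 1.5-fold lower number from compound 2 to compound 4 (0.16 log units; within the scatter)), so a terminal amino group on the chain does not by itself go with a higher number among these compounds. The clear separation lies at the saturated chain carbon bound to two saturated chain carbons, where hydroxy in place of amino gives a step beyond the scatter (an 8.7-fold lower number from compound 1 to compound 4 (0.94 log units; beyond the scatter)), which places the higher number of compound 1 on the amino group at that carbon rather than on amino groups in general.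

Nothing available explains why the two amino placements read so differently.

Going by these compounds, it remains open whether a dimethylamino group or a carboxylic acid at the end of the 3-amino-2-hydroxypropyl chain would stay level with compound 4. On these data alone, it is equally open whether a longer chain, with the amino group further from the hydroxy group, would do so.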